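Compound 1 without its methoxy

The source may report more compounds than this note shows. Statements on the series, on what has been measured and on what is new or still open speak of the compounds shown alone.

In a functional assay on UO-31 cells (Homo sapiens) for inhibition, read by sulforhodamine B assay, with a stated time of 48 h, tested at 10 uM (on this read-out lower numbers stand for less inhibition of growth and higher numbers for more inhibition of growth at the one concentration tested), compound 1 (`COc1ccc(-c2nc3sc(-c4ccccc4)cn3n2)cc1`) gives 38%. Compound 2 (`COc1cc(-c2nc3sc(-c4ccccc4)cn3n2)cc(OC)c1OC`) gives 43%, within the scatter of compound 1, and these two form the upper pair of the three numbers. Compound 3 (`COc1ccc(-c2nc3sc(-c4ccc(Cl)cc4)cn3n2)cc1`) gives -7.46%, far under that pair.

Compound 4 (`c1ccc(-c2nc3sc(-c4ccccc4)cn3n2)cc1`) is the next case: hydrogen in place of methoxy on an aromatic carbon. Going by the values given here, the only measured step, a number 45.5 percentage points lower from compound 1 to compound 3 (beyond the scatter), is large, but it is chloro in place of hydrogen and leaves the methoxy untouched. It shows that one substitution can move these numbers far, without fixing a direction here. A moderately lower number is expected, tentatively, with a wide range. The expected step is a number 13 percentage points lower from compound 1 to compound 4 (beyond the scatter). For compound 4 the estimate is 25%, with an expected range of -5% to 50%.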

Compound 4, percent growth inhibition at one concentration: 53%
Compound 4: the middle estimate sits 28 percentage points below what was measured; the whole stated range lies below it.
By their numbers in this assay, from the lowest: compound 3; then compounds 1, 2 and 4 (each within the scatter of the next, the first and the last beyond it).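

In this assay hydrogen in place of methoxy gives a number 15 percentage points higher from compound 1 to compound 4 (beyond the scatter) and so shows that inhibition of growth at this position does not depend on the methoxy. Going by these compounds alone, this is the first measured change at this place on the six-membered aromatic ring, and its direction is upward, opposite to the only earlier step. Nothing measured here explains that direction.

As far as these compounds go, whether an amine, a carboxylic acid or a longer chain at this position would keep, raise or lower the number remains open. Also open, from the compounds shown here alone, is whether chloro in place of hydrogen would have the same effect on compound 4.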